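The source may report more compounds than this note shows. Statements on the series, on what has been measured and on what is new or still open speak of the compounds shown alone.

Measured in an assay on HEK293 cells for displacement of a labelled ligand from metabotropic glutamate receptor 5 (Homo sapiens), with a stated time of 2 h; a lower number here means a stronger inhibitor, a higher number a weaker inhibitor:

- compound 1 `Cc1cccc(C#Cc2ccc3c(n2)CCN(C)C3=O)c1`: 820 nM
- compound 2 `COc1cccc(C#Cc2ccc3c(n2)CCN(C)C3=O)c1`: 3660 nM
- compound 3 `CN1CCc2nc(C#Cc3ccccn3)ccc2C1=O`: 6240 nM

Among these three, compound 1 has the lowest number and is therefore the strongest binder of the set. Its nearest neighbour is compound 2, reached by a 4.5-fold higher number from compound 1 to compound 2 (0.65 log units; beyond the scatter). Further away is compound 3, reached by a 7.6-fold higher number from compound 1 to compound 3 (0.88 log units; beyond the scatter). Both of these steps alter the ring hanging off the triple-bonded carbon at one end of the shared core.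

Compound 4 `Cc1cccc(C#Cc2ccc3c(n2)CCN(C2CCCC2)C3=O)c1` changes compound 1 at the opposite end: cyclopentyl in place of methyl on an amide-type nitrogen in a ring. Within the data shown here, no measured step touches this amide-type nitrogen, so neither of the two known steps bears directly on the change. The measured steps only show that altering the distant aromatic end costs a modest amount in this assay; they give no guide to what a larger group on the ring nitrogen does. The expectation is therefore a small step of uncertain direction, with the range kept wide. Compound 4 is estimated at 1200 nM, between 300 nM and 5000 nM. This estimate means a 1.5-fold higher number from compound 1 to compound 4 (0.17 log units; within the scatter), expected rather than known.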

Compound 4, inhibition constant: 670 nM
For compound 4 the middle estimate is 1.8-fold (0.25 log units) above the measured one; the measured number falls inside the stated range.
By their numbers in this assay, from the lowest: compounds 4 and 1 (each within the scatter of the next); then compounds 2 and 3 (each within the scatter of the next).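

In this assay, placing cyclopentyl instead of methyl on the amide-type nitrogen in a ring gives a 1.2-fold lower number from compound 1 to compound 4 (0.09 log units; within the scatter), so this change cannot be told apart from the ordinary spread of repeated measurements. Among these compounds, this is the first measured change at this nitrogen, and it shows that a group of 5 heavy atoms including a ring can replace one of 1 heavy atom with no measurable shift in the number, whereas the earlier changes on an aromatic carbon and on a triple-bonded carbon gave a 4.5-fold higher number from compound 1 to compound 2 (0.65 log units; beyond the scatter) and a 7.6-fold higher number from compound 1 to compound 3 (0.88 log units; beyond the scatter), both beyond the scatter. No outside evidence bears on why this nitrogen tolerates the change.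

From the compounds shown here alone, only methyl and cyclopentyl appear on this nitrogen, both made of carbon alone, so what a phenyl ring, a longer chain ending in an amine, or a carboxylic acid would do there remains open. Going by these compounds, it is also open whether cyclopentyl on this nitrogen would leave the number unmoved when methoxy or pyridin-2-yl stands in the other changed place.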